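The source may hold more compounds than are shown below. What is called first, only, known or untested is meant among the compounds shown, and "the series" means these compounds.

Working notes on the series. Compound 1 `Fc1ccc(-c2cn3ccnc3c(-c3ccc4ncn(C5CCCCC5)c4c3)n2)cc1` and compound 2 `Fc1ccccc1-c1cn2ccnc2c(-c2ccc3ncn(C4CCCCC4)c3c2)n1` share one core and differ only in the aryl group carried on it. In a functional assay on NCI-H460 cells (Homo sapiens) for inhibition, read by sulforhodamine B assay, with a stated time of 48 h, tested at 10 uM (on this read-out lower numbers stand for less inhibition and higher numbers for more inhibition at the one concentration tested (going by the name of the read-out)), compound 1 gives 6.12%, and in the same test compound 2 gives 8.1%. Among the measured compounds shown here, the only step measured so far, a number 2 percentage points higher from compound 1 to compound 2 (within the scatter), comes with 2-fluorophenyl in place of 4-fluorophenyl on an aromatic carbon and lies within the scatter, so the two numbers cannot be told apart. Compound 2 has the higher of the two numbers, but the gap to compound 1 is within the scatter and no order can be claimed; both sit at the low end of this assay.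

Compound 3 `FC(F)(F)c1cccc(-c2cn3ccnc3c(-c3ccc4ncn(C5CCCCC5)c4c3)n2)c1` is next. The change 3-(trifluoromethyl)phenyl in place of 2-fluorophenyl on an aromatic carbon again exchanges the aryl group on the same aromatic carbon. For the measured compounds named here, the one step that bears on it, from compound 1 to compound 2, was within the scatter, and nothing measured speaks for a larger move with a trifluoromethyl-bearing aryl. The expected step of a number 1.9 percentage points higher from compound 2 to compound 3 (within the scatter) is therefore none beyond the scatter. Compound 3 is estimated at 10% in this assay, within 0% to 28%.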

Compound 3, a percentage reported as inhibition, at one concentration (the size of the read-out at that concentration, not a potency): 4.38%
The estimate for compound 3 lay 5.6 percentage points above the measured number; low and high end bracket the measured number.
By their numbers in this assay, from the lowest: compounds 3, 1 and 2 (each within the scatter of the next).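

At this aromatic carbon, this assay gives a number 3.7 percentage points lower from compound 2 to compound 3 (within the scatter) for 3-(trifluoromethyl)phenyl in place of 2-fluorophenyl and a number 1.7 percentage points lower from compound 1 to compound 3 (within the scatter) for 3-(trifluoromethyl)phenyl in place of 4-fluorophenyl. Among the compounds shown here, the earlier pair covered only two fluorophenyl groups, whereas these steps extend the same reading to a trifluoromethyl-bearing aryl group, so none of the three pairs can be told apart and no order among the three aryl groups can be claimed. Nothing available explains why the numbers stay together.

From the compounds shown here alone, all three compounds carry a fluorine-bearing phenyl group at this position, so it stays open whether a phenyl group bearing an amine or a carboxylic acid, or a longer alkyl chain in place of the aryl group, would give a number in this assay that stands clear of the scatter. Also open is whether any group at this carbon matters at all on this read-out, since the three aryl groups shown give no step beyond the scatter to build on.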